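This account rests on a few compounds, and the source may have more. Where it says the series, first, only, none or still open, it means among the compounds named here.

Among the measured compounds shown here, compound 1 `O=c1c2cnn(-c3ccc(F)cc3)c2ncn1CC1(O)CCN(Cc2ccccc2Br)CC1` is the only compound with a number here: in an assay on Sf21 cells for inhibition of ubiquitin carboxyl-terminal hydrolase 7 (Homo sapiens), read by spectrophotometry, with stated times of 30 min and 2 h (a lower number here means a stronger inhibitor, a higher number a weaker inhibitor), compound 1 gives 3100 nM. Compound 2 `O=c1c2cnn(-c3ccc(F)cc3)c2ncn1CC1(O)CCN(Cc2cc(F)cc(F)c2)CC1` was also tested in this assay, but for compound 2 the result is "not determined" (no result reported), so nothing can be compared against it. Compound 3 `O=c1c2cnn(-c3ccc(F)cc3)c2ncn1CC1(O)CCN(Cc2ccc(F)cc2Cl)CC1` differs from compound 1 by 2-chloro-4-fluorophenyl in place of 2-bromophenyl on a saturated chain carbon bound to an amine nitrogen in a ring. For the measured compounds named here, no step between two measured compounds is available to calibrate this change, so the step in this assay is expected to be small and within the usual scatter, without a clear direction, so that from compound 1 to compound 3 the estimated change is a 1.0-fold lower number from compound 1 to compound 3 (0.01 log units; within the scatter). Compound 3 is therefore expected to give about 3000 nM in this assay, with a likely range from 1000 nM to 9000 nM.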

Compound 3, half-maximal inhibitory concentration: 1600 nM
For compound 3 the middle estimate is 1.9-fold (0.27 log units) above the measured one; low and high end bracket the measured number.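

In this assay, among the compounds shown here, 2-chloro-4-fluorophenyl in place of 2-bromophenyl on a saturated chain carbon bound to an amine nitrogen in a ring gives a 1.9-fold lower number from compound 1 to compound 3 (0.29 log units; within the scatter) and is the first step that can be read at this position. This one exchange of halogen-bearing phenyl groups therefore leaves the number within the scatter. No measurement shown bears on the reason for this result.

Any step to compound 2 cannot be read. From the compounds shown here alone, it remains open whether an amine or a carboxylic acid on this phenyl ring, or a longer chain in place of the benzyl carbon, would shift the number beyond the scatter.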